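The source may report more compounds than this note shows. Statements on the series, on what has been measured and on what is new or still open speak of the compounds shown alone.

Compound 3 `O=C1c2ccccc2C(=O)N1C/C=C/Cn1cc(C#CCCc2ccccc2)c(=O)[nH]c1=O` carries a phenethyl group on the alkyne, and in a functional assay on MIA PaCa-2 cells (Homo sapiens) for antiproliferative activity, read by MTT assay, with a stated time of 3 days (a higher number here means a weaker inhibitor, a lower number a stronger inhibitor), compound 3 gives 27000 nM. Compound 1 `CCCCc1ccc(C#Cc2cn(C/C=C/CN3C(=O)c4ccccc4C3=O)c(=O)[nH]c2=O)cc1` differs by 4-butylphenyl in place of phenethyl on a triple-bonded carbon, and in this assay compound 1 gives 79000 nM, a loss of a 2.9-fold higher number from compound 3 to compound 1 (0.47 log units; beyond the scatter). Compound 2 `O=C1c2ccccc2C(=O)N1C/C=C\Cn1cc(C#CCCc2ccccc2)c(=O)[nH]c1=O` shares every atom with compound 3, the difference being (the two compounds have the same atoms and bonds and differ only in configuration as drawn: 1 of 1 stereo elements differ; a double bond is drawn E in compound 3 and Z in compound 2). In this assay compound 2 reaches only a limit, > 100000 nM. The step of an at least 3.7-fold lower number from compound 2 to compound 3 (0.56 log units; beyond the scatter) is therefore bounded because of the limit of > 100000 nM in this assay, at which 1 of the 3 values shown sits, and rests on (the fact that compounds 2 and 3 differ only in the configuration as drawn). Compound 4 `CCCCc1ccc(C#Cc2cn(C/C=C\CN3C(=O)c4ccccc4C3=O)c(=O)[nH]c2=O)cc1` is not yet measured; against compound 2 it carries 4-butylphenyl in place of phenethyl on a triple-bonded carbon, the same change as in the measured pair. The step from compound 2 to compound 4 is expected to be a step that the limit leaves unreadable from compound 2 to compound 4, matching the measured one. Compound 4 is thus expected to give 250000 nM, between 100000 nM and 600000 nM, most likely again as a limit.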

Compound 4, half-maximal inhibitory concentration: 56000 nM
The estimate for compound 4 lay 4.5-fold (0.65 log units) above the measured number, outside the stated range (below it).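

In this assay, the change from phenethyl to 4-butylphenyl did not carry over from the core of compound 3 to the core of compound 2, as the two steps run in opposite directions: the same change on two cores in this assay, a 2.9-fold higher number (0.47 log units; beyond the scatter) from compound 3 to compound 1 and an at least 1.7-fold lower number (0.25 log units; that floor lies within the scatter) from compound 2 to compound 4, at least 5.2-fold (0.71 log units) apart, beyond the scatter of two such steps. The second step, an at least 1.7-fold lower number from compound 2 to compound 4 (0.25 log units; that floor lies within the scatter), is only a floor set by a limit, so its true size cannot be read: the limit of > 100000 nM in this assay, at which 1 of the 4 values shown sits. With 4-butylphenyl, the two double-bond forms show a 1.4-fold lower number from compound 1 to compound 4 (0.15 log units; within the scatter), but this single pair does not explain the difference between the cores: the fact that compounds 1 and 4 differ only in the configuration as drawn.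

From the compounds shown here alone, it remains open whether the same divergence would appear with other groups on the triple-bonded carbon, such as a longer alkyl chain, or a phenyl ring bearing an amine or a carboxylic acid.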